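Chalcone-linked series: methoxy substitution on the aryl group

The compounds below may be only part of what the source reports. "The series", "measured", "known", "first", "only" and "open" are said of these compounds alone.

Measured compounds:
- compound 1 `O=C(/C=C/c1cccc(O)c1)c1cccc(-n2cc(-c3ccc(Cl)cc3)[nH]c2=O)c1`, in a functional assay on Hs-578T cells (Homo sapiens) for inhibition (a higher number here means a weaker inhibitor of growth, a lower number a stronger inhibitor of growth), compound 1 gives 4000 nM
- compound 2 `COc1cc(/C=C/C(=O)c2cccc(-n3cc(-c4ccccc4)[nH]c3=O)c2)cc(OC)c1OC`, in this assay compound 2 gives 3410 nM

Compound 2 has the lowest of the two numbers in this assay. Its nearest neighbour is compound 1, which gives a slightly higher number; the gap between the two lies within the scatter of repeated measurements, so no ordering between compound 1 and compound 2 can be claimed from these values. Within the data shown here, compound 1 and compound 2 differ in more than one place, and no single step between them is available.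

Compound 3 `COc1ccc(-c2cn(-c3cccc(C(=O)/C=C/c4cc(OC)c(OC)c(OC)c4)c3)c(=O)[nH]2)cc1` is not yet measured. It differs from compound 2 in one place: methoxy in place of hydrogen on an aromatic carbon. Among the measured compounds shown here, no measured step with this change exists, so the expectation rests only on the size of the change and the values of compound 1 and compound 2. A small step is expected, not beyond the scatter, in either direction. For compound 3 the estimated value in this assay is 3000 nM, with a range from 1200 nM to 7500 nM, which means an expected step of a 1.1-fold lower number from compound 2 to compound 3 (0.06 log units; within the scatter).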

Compound 3, concentration for 50% growth inhibition: 3390 nM
Compound 3: the middle estimate sits 1.1-fold (0.05 log units) below what was measured; low and high end bracket the measured number.
By their numbers in this assay, from the lowest: compounds 3, 2 and 1 (each within the scatter of the next).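

In this assay, methoxy in place of hydrogen on an aromatic carbon, para to a large group (phenyl to 4-methoxyphenyl), gives a 1.0-fold lower number from compound 2 to compound 3 (0.00 log units; within the scatter). Among these compounds, this is the first single-place reading, which compound 1 and compound 2 could not provide, as they differ in more than one place. At this position, the added methoxy gives no step beyond the scatter, and no measurement offered here accounts for that result.

On these data alone, whether the same holds for other groups at this position, such as an amine, a carboxylic acid or a longer chain such as butoxy, remains open. Among the compounds shown here, this single step also leaves open whether methoxy in place of hydrogen would read the same alongside the hydroxy-bearing aryl group of compound 1, since the only reading so far comes from the pair compound 2 and compound 3.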